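Swapping the urea end of compound 3 for a methylpiperazinyl carbonyl

The compounds below may be only part of what the source reports. "The series", "measured", "known", "first", "only" and "open" are said of these compounds alone.

Of the compounds shown here, three sharing one core have been tested in a functional assay on DU-145 cells (Homo sapiens) for antiproliferative activity, read by MTT assay, with a stated time of 3 days; on this read-out higher numbers stand for weaker inhibition and lower numbers for stronger inhibition. Compound 1 `COc1cc(O)c2c(=O)cc(-c3ccc(NS(=O)(=O)C4CC4)cc3)oc2c1OC(C)C` gives 48700 nM. Compound 2 `C=CC(=O)Nc1ccc(-c2cc(=O)c3c(O)cc(OC)c(OC(C)C)c3o2)cc1` gives 14700 nM. Compound 3 `COc1cc(O)c2c(=O)cc(-c3ccc(NC(=O)NC4CC4)cc3)oc2c1OC(C)C` gives 15600 nM, which puts it second highest of the three: it sits within the scatter of compound 2 and is separated from compound 1 by a 3.1-fold lower number from compound 1 to compound 3 (0.49 log units; beyond the scatter). The other two steps are a 3.3-fold lower number from compound 1 to compound 2 (0.52 log units; beyond the scatter) and a 1.1-fold higher number from compound 2 to compound 3 (0.03 log units; within the scatter).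

Compound 4 `COc1cc(O)c2c(=O)cc(-c3ccc(NC(=O)N4CCN(C)CC4)cc3)oc2c1OC(C)C` differs from compound 3 in one place: 4-methylpiperazin-1-yl in place of cyclopropylamino on a carbonyl carbon. For the measured compounds named here, no measured pair shows this exact exchange. The closest guidance is the step of a 1.1-fold higher number from compound 2 to compound 3 (0.03 log units; within the scatter), where the group on the carbonyl carbon was changed with no shift beyond the scatter, whereas the larger shifts came from changing what sits on the aromatic nitrogen itself. The carbonyl-attached nitrogen remains in compound 4, so a small step is expected, at most modest in either direction.

Compound 4 is therefore estimated at 20000 nM, with a range from 7000 nM to 60000 nM, corresponding to an expected step of a 1.3-fold higher number from compound 3 to compound 4 (0.11 log units; within the scatter).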

Compound 4, half-maximal inhibitory concentration: 12500 nM
The estimate for compound 4 lay 1.6-fold (0.20 log units) above the measured number; the measured number falls inside the stated range.
By their numbers in this assay, from the lowest: compounds 4, 2 and 3 (each within the scatter of the next); then compound 1.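

In this assay, the carbonyl carbon accepted a bulkier group with no shift beyond the scatter: 4-methylpiperazin-1-yl, with a six-membered ring and no hydrogen-bond donor, replaced cyclopropylamino in a 1.2-fold lower number from compound 3 to compound 4 (0.10 log units; within the scatter) and vinyl in a 1.2-fold lower number from compound 2 to compound 4 (0.07 log units; within the scatter). For the compounds shown here, on this position, the three groups cannot be told apart, and the only step beyond the scatter is the one that leaves cyclopropylsulfonyl on the aromatic nitrogen, a 3.9-fold lower number from compound 1 to compound 4 (0.59 log units; beyond the scatter), which is no larger in kind than those from compound 1 to the other two compounds. No measurement is available to explain why these groups read alike.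

The compounds shown leave open whether a morpholine ring or a longer chain ending in a carboxylic acid on this carbonyl carbon would move the number beyond the scatter. They also leave open whether the aromatic nitrogen itself must be kept.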